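Nitrophenyl isomers: from compound 3 to compound 4

This account rests on a few compounds, and the source may have more. Where it says the series, first, only, none or still open, it means among the compounds named here.

In a functional assay on HeLa cells (Homo sapiens) for inhibition, read by MTT assay, with a stated time of 72 h (on this read-out lower numbers stand for stronger inhibition and higher numbers for weaker inhibition), compound 1 (`COc1cc(O)c(CC=C(C)C)c(O)c1C(=O)/C=C/c1ccc(O)c(O)c1`) gives 38100 nM, compound 2 (`COc1cc(O)c(CC=C(C)C)c(O)c1C(=O)/C=C/c1ccc(Cl)cc1`) gives 16500 nM and compound 3 (`COc1cc(O)c(CC=C(C)C)c(O)c1C(=O)/C=C/c1ccc([N+](=O)[O-])cc1`) gives 29700 nM. Compound 3 stands within the scatter of both others, with a 1.3-fold lower number from compound 1 to compound 3 (0.11 log units; within the scatter) and a 1.8-fold higher number from compound 2 to compound 3 (0.26 log units; within the scatter). The one separation beyond the scatter is modest: a 2.3-fold lower number from compound 1 to compound 2 (0.36 log units; beyond the scatter).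

Next is compound 4 (`COc1cc(O)c(CC=C(C)C)c(O)c1C(=O)/C=C/c1cccc([N+](=O)[O-])c1`), with 3-nitrophenyl in place of 4-nitrophenyl on a double-bonded chain carbon bound to a double-bonded chain carbon. Going by the values given here, no measured step shifts a group from one ring position to another, so the evidence for this change is indirect. Among the compounds with values here, the steps that bear on it are the exchanges of the whole aryl group or its substituent. These are small, and two of the three stay within the scatter. The largest, a 2.3-fold lower number from compound 1 to compound 2 (0.36 log units; beyond the scatter), replaces 3,4-dihydroxyphenyl with 4-chlorophenyl, a larger change than the one considered here. No step beyond the scatter is therefore expected in this assay. The expected step is a 1.1-fold lower number from compound 3 to compound 4 (0.04 log units; within the scatter). For compound 4 the estimated value is 27000 nM, with an expected range of 14000 nM to 52000 nM.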

Compound 4, half-maximal inhibitory concentration: 16500 nM
Compound 4: the middle estimate sits 1.6-fold (0.21 log units) above what was measured; the measured number falls inside the stated range.
By their numbers in this assay, from the lowest: compounds 2, 4, 3 and 1 (each within the scatter of the next, the first and the last beyond it).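

In this assay, the first measured shift of the nitro group around the ring (a 1.8-fold lower number from compound 3 to compound 4 (0.26 log units; within the scatter)) leaves 3-nitrophenyl and 4-nitrophenyl unresolved at this place on the chain, so these compounds show no preference between the two arrangements. The 3-nitrophenyl compound also cannot be told apart from the 4-chlorophenyl compound (no change at the digits printed from compound 2 to compound 4 (within the scatter)), yet it separates modestly from the 3,4-dihydroxyphenyl compound (a 2.3-fold lower number from compound 1 to compound 4 (0.36 log units; beyond the scatter)), whereas the 4-nitrophenyl compound stays within the scatter of that same compound (a 1.3-fold lower number from compound 1 to compound 3 (0.11 log units; within the scatter)); since compound 3 and compound 4 are themselves unresolved, this contrast does not amount to an effect of nitro position. Nothing available accounts for these small differences, and the isomer pair alone supports no explanation.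

Going by these compounds, whether an amine or a carboxylic acid in place of the nitro group on this ring would produce a larger step in this assay remains open. Also open, on these data alone, is whether the near-equivalence of 3-nitrophenyl and 4-nitrophenyl would persist with a methoxy group or a longer chain elsewhere on the shared core.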